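This account rests on a few compounds, and the source may have more. Where it says the series, first, only, none or still open, it means among the compounds named here.

Measured in a functional assay on A549 cells (Homo sapiens) for cytotoxicity, read by MTT assay, with a stated time of 48 h; a higher number here means a weaker inhibitor, a lower number a stronger inhibitor:
- Compound 1 `C=C1C(=O)O[C@H]2CC3=C[C@H](C/C(C)=C/[C@@H](OC(=O)c4ccc([N+](=O)[O-])cc4)[C@H]12)OC3=O`: > 10000 nM, a limit of the assay
- Compound 2 `C=C1C(=O)O[C@H]2CC3=C[C@H](C/C(C)=C/[C@@H](OC(=O)c4ccc(C(C)=O)cc4)[C@H]12)OC3=O`: 2300 nM
- Compound 3 `C=C1C(=O)O[C@H]2CC3=C[C@H](C/C(C)=C/[C@@H](OC(=O)/C=C/c4ccc(N(C)C)cc4)[C@H]12)OC3=O`: > 10000 nM, a limit of the assay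

Compound 2 is the only one of the three with an exact number, and it is the most active of them. The other two results are the limit of > 10000 nM in this assay, at which 2 of the 3 values shown sit.

Compound 4 `C=C1C(=O)O[C@H]2CC3=C[C@H](C/C(C)=C/[C@@H](OC(=O)CCCCC)[C@H]12)OC3=O` has not been measured. It differs from compound 2 as follows: pentyl in place of 4-acetylphenyl on a carbonyl carbon. In words, this is pentyl in place of 4-acetylphenyl on a carbonyl carbon.

The closest measured change, at that same carbonyl carbon, is an at least 4.3-fold higher number from compound 2 to compound 3 (0.63 log units; beyond the scatter). A change further out in the same group, on an aromatic carbon, gave an at least 4.3-fold lower number from compound 1 to compound 2 (0.63 log units; beyond the scatter). Both steps show that this group matters, and compound 3 suggests that replacing 4-acetylphenyl can cost activity. A modest rise in the number is therefore expected in this assay, meaning a weaker compound. The estimated change is a 2.2-fold higher number from compound 2 to compound 4 (0.34 log units; beyond the scatter). The estimate for compound 4 is 5000 nM, with an expected range of 1500 nM to 15000 nM.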

Compound 4, half-maximal inhibitory concentration: > 10000 nM
Compound 4: only a limit was reported; the forecaster's own chance of this, stated with the estimate: 35%; at least 2.0-fold (0.30 log units) between middle value and limit.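

In this assay, pentyl in place of 4-acetylphenyl on this carbonyl carbon gives an at least 4.3-fold higher number from compound 2 to compound 4 (0.63 log units; beyond the scatter). Activity here therefore falls with a chain that has no ring, as it does with the 2-(4-(dimethylamino)phenyl)ethenyl group of compound 3. The steps among compound 1, compound 3 and compound 4 cannot be read, because all three sit at a limit of the assay: the limit of > 10000 nM in this assay, at which 3 of the 4 values shown sit.

Still open, on these data alone, is whether a methoxy group or an amine in place of the acetyl on the aromatic ring keeps a measurable value. A cyclohexyl ring or a longer chain on the carbonyl carbon also remains untested among the compounds shown.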